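Shifting the aryl substituent on the seven-membered core

This account rests on a few compounds, and the source may have more. Where it says the series, first, only, none or still open, it means among the compounds named here.

Measured so far:
- compound 1 `Cc1cccc(NC(=O)N[C@@H]2C[C@H](c3ccc(F)cc3)C[C@H](c3ccccc3)N(CC(=O)NC(C)(C)C)C2=O)c1`: 700 nM
- compound 2 `Cc1ccc([C@@H]2C[C@H](c3ccccc3)N(CC(=O)NC(C)(C)C)C(=O)[C@H](NC(=O)Nc3cccc(C)c3)C2)cc1`: 1.1 nM
- compound 3 `Cc1cccc(NC(=O)N[C@@H]2C[C@H](c3ccccc3C)C[C@H](c3ccccc3)N(CC(=O)NC(C)(C)C)C2=O)c1`: 610 nM; 580 nM; 930 nM (3 entries)

In an assay on isolated protein for inhibition of Cholecystokinin receptor type A (Cavia porcellus) (a lower number here means a stronger inhibitor, a higher number a weaker inhibitor), compound 2 gives the lowest number of the two single values; its nearest neighbour is compound 1, and the step of a 640-fold lower number from compound 1 to compound 2 (2.80 log units; beyond the scatter) is large. Compound 3 shows far higher numbers, as the several entries of compound 3 in this assay, 610 nM; 580 nM; 930 nM (3 entries) records, and it carries its methyl on the same position that the ethyl of compound 4 will occupy. Compound 4 `CCc1ccccc1[C@@H]1C[C@H](c2ccccc2)N(CC(=O)NC(C)(C)C)C(=O)[C@H](NC(=O)Nc2cccc(C)c2)C1` differs from compound 2 by 2-ethylphenyl in place of 4-methylphenyl on a saturated ring carbon. Since compound 3 gives 610 nM; 580 nM; 930 nM (3 entries) while compound 2 gives 1.1 nM, a substituent at that position appears to go with much higher numbers, so compound 4 is expected to sit near compound 3. Compound 4 is therefore estimated at 600 nM (range 100 nM to 3000 nM), a step of a 550-fold higher number from compound 2 to compound 4 (2.74 log units; beyond the scatter).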

Compound 4, half-maximal inhibitory concentration: 810 nM
Compound 4: middle estimate off by 1.4-fold (0.13 log units), on the low side; the measured number falls inside the stated range.
By their numbers in this assay, from the lowest: compound 2; then compounds 1 and 4 (each within the scatter of the next).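

Putting 2-ethylphenyl in place of 4-methylphenyl on this saturated ring carbon gives a 740-fold higher number from compound 2 to compound 4 (2.87 log units; beyond the scatter), so the very low number of compound 2 does not extend to every substituted phenyl here. Putting 2-ethylphenyl in place of 4-fluorophenyl gives only a 1.2-fold higher number from compound 1 to compound 4 (0.06 log units; within the scatter), leaving 4-methylphenyl alone among these groups with a low number. Compound 3 stays in the same high range, as recorded by: the several entries of compound 3 in this assay, 610 nM; 580 nM; 930 nM (3 entries)

As far as these compounds go, whether a 4-ethylphenyl would keep the low number of compound 2 remains open. So does the effect of a 4-methoxyphenyl or a 4-aminophenyl at this ring carbon.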